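The source may report more compounds than this note shows. Statements on the series, on what has been measured and on what is new or still open speak of the compounds shown alone.

Working notes on the amide series. Compound 1 `CC1=C(/C=C/C(C)=C/C=C/C(C)=C\C(=O)NCc2ccc(F)cc2)C(C)(C)CCC1n1ccnc1` gives 1930 nM in a functional assay on MCF7 cells (Homo sapiens) for inhibition, read by MTT assay; a lower number here means a stronger inhibitor of growth, a higher number a weaker inhibitor of growth. Compound 2 `CC1=C(/C=C/C(C)=C/C=C/C(C)=C\C(=O)Nc2ccc(F)cc2)C(C)(C)CCC1n1ccnc1` gives 400 nM in this assay, and compound 3 `CC1=C(/C=C/C(C)=C/C=C/C(C)=C\C(=O)Nc2ccccc2)C(C)(C)CCC1n1ccnc1` gives 1900 nM. Among the three numbers compound 3 stands second highest: it sits nearest compound 1, within the scatter, and furthest from compound 2, which is a 4.8-fold higher number from compound 2 to compound 3 (0.68 log units; beyond the scatter). The other steps read a 4.8-fold lower number from compound 1 to compound 2 (0.68 log units; beyond the scatter) and a 1.0-fold lower number from compound 1 to compound 3 (0.01 log units; within the scatter).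

The next compound, compound 4 `CC1=C(/C=C/C(C)=C/C=C/C(C)=C\C(=O)NCc2cccc(F)c2)C(C)(C)CCC1n1ccnc1`, differs from compound 3 by 3-fluorobenzyl in place of phenyl on an amide-type nitrogen. Within the data shown here, two measured steps bear on this. The step from compound 1 to compound 3 shows that exchanging 4-fluorobenzyl for phenyl on the amide-type nitrogen left the number where it was, so the benzyl spacer itself did not move the read-out. The step from compound 2 to compound 3 shows that removing fluoro from the aromatic carbon of an anilide cost a modest amount, but that was on the phenyl, not on a benzyl, and compound 1 with 4-fluorobenzyl matched compound 3. There is no measurement for a fluoro in the 3-position of a benzyl group. The expectation is therefore a step of a 1.1-fold lower number from compound 3 to compound 4 (0.02 log units; within the scatter), with the number for compound 4 estimated at 1800 nM, in a range from 700 nM to 4500 nM.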

Compound 4, concentration for 50% growth inhibition: 1810 nM
The estimate for compound 4 lay 1.0-fold (0.00 log units) below the measured number; measured number inside the range.
By their numbers in this assay, from the lowest: compound 2; then compounds 4, 3 and 1 (each within the scatter of the next).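

Exchanging 4-fluorobenzyl for 3-fluorobenzyl on the amide-type nitrogen leaves the read-out in this assay unresolved (a 1.1-fold lower number from compound 1 to compound 4 (0.03 log units; within the scatter)), so among these benzyl amides the two fluoro placements cannot be told apart. The 3-fluorobenzyl amide also cannot be separated from the plain phenyl amide (a 1.0-fold lower number from compound 3 to compound 4 (0.02 log units; within the scatter)), which places three of the four compounds in one group. Only the 4-fluorophenyl amide stands apart from this new benzyl amide (a 4.5-fold higher number from compound 2 to compound 4 (0.66 log units; beyond the scatter)), so a fluoro on the benzyl group, in either of the two placements shown, does not reproduce the separation seen with 4-fluorophenyl.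

As far as these compounds go, it remains open whether a 3-fluorophenyl group on the same nitrogen would keep that separation, which would test whether it depends on the fluoro placement on the anilide. Also open is how an unsubstituted benzyl group, a 4-methoxyphenyl group or a longer chain such as 2-phenylethyl would read against these four compounds, and no measured information shown here accounts for any of these numbers.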